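The compounds below may be only part of what the source reports. "The series", "measured", "known", "first", "only" and "open" are said of these compounds alone.

Measured so far:
Compound 1 `CC(=O)NCc1ncc2cc(COc3ccc(C(=O)NCc4cccnc4)cc3)n(CCC3CCCCC3)c2n1`: 77 nM
Compound 2 `Nc1ccc(CNC(=O)Nc2ccc(CN3C(=O)c4ccccc4C3=O)cc2)cn1`: 57 nM

In a functional assay on COR-L23 cells (Homo sapiens) for antiproliferative activity, read by CellTiter-Glo, with a stated time of 4 days (on this read-out higher numbers stand for weaker inhibition and lower numbers for stronger inhibition), compound 2 gives 57 nM, within the scatter of compound 1 at 77 nM. The next compound to be tested is compound 3 `O=C(CCc1cccnc1)Nc1ccc(CN2C(=O)c3ccccc3C2=O)cc1`, which carries 2-(pyridin-3-yl)ethyl in place of ((6-aminopyridin-3-yl)methyl)amino on a carbonyl carbon. Among the compounds with values here, no two measured compounds differ in only one place, so the data offer no step to serve as a guide. No change beyond the scatter is therefore expected in this assay. The estimated step is a 1.4-fold lower number from compound 2 to compound 3 (0.15 log units; within the scatter). For compound 3 the estimated value is 40 nM, with an expected range from 8 nM to 200 nM.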

Compound 3, half-maximal inhibitory concentration: > 10000 nM
Compound 3: only a limit was reported; the forecaster's own chance of this, stated with the estimate: 3%; middle value at least 250-fold (2.39 log units) from the limit.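

With 2-(pyridin-3-yl)ethyl in place of ((6-aminopyridin-3-yl)methyl)amino on a carbonyl carbon, this assay shows an at least 170-fold higher number from compound 2 to compound 3 (2.24 log units; beyond the scatter), the first sign that the result depends heavily on the group at this place. The value of compound 3 is a limit and not a number: the limit of > 10000 nM in this assay, at which 1 of the 3 values shown sits.

As far as these compounds go, the change removes the ring amine and the nitrogen on the carbonyl together, so which of the two matters stays open. A (pyridin-3-yl)methylamino group, which keeps that nitrogen and lacks the ring amine, would separate them.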